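A Piperidine Ether on a Shared Core

The source may report more compounds than this note shows. Statements on the series, on what has been measured and on what is new or still open speak of the compounds shown alone.

Measured so far:
compound 1 `COc1cc(OC)c2c(=O)cc(-c3ccc(OCCF)cc3)oc2c1`: "not active" (no number reported)
compound 2 `COc1cc(OC)c2c(=O)cc(-c3ccc(OCCN4CCCC4=O)cc3)oc2c1`: 7%

Among the measured compounds shown here, in a functional assay (Homo sapiens) for antiproliferative activity, read by resazurin assay, with a stated time of 48 h, tested at 5 uM (on this read-out lower numbers stand for a weaker effect and higher numbers for a stronger effect at the one concentration tested), compound 2 gives 7% and is the only compound with a number, since compound 1 was reported without one. Compound 3 `COc1cc(OC)c2c(=O)cc(-c3ccc(OC4CCNCC4)cc3)oc2c1` is compound 2 with one change, (piperidin-4-yl in place of 2-(2-oxopyrrolidin-1-yl)ethyl on an oxygen on an aromatic ring). For the measured compounds named here, no step between two measured compounds is known here, so the change is expected to move the read-out by no more than the usual scatter, giving an expected step of a number 3 percentage points higher from compound 2 to compound 3 (within the scatter). Compound 3 is therefore estimated at 10%, with a range from 0% to 30%.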

Compound 3, a percentage reported as inhibition, at one concentration (the size of the read-out at that concentration, not a potency): "not active" (no number reported)
The entry for compound 3 holds no number, so the estimate cannot be set against anything.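

Among the compounds shown here, compound 3 carries no number in this assay, so no step from compound 2 to compound 3 can be read. As far as these compounds go, whether piperidin-4-yl in place of 2-(2-oxopyrrolidin-1-yl)ethyl changes the effect stays open, and no other measurement bears on this result.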